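Aryl swap on the piperidine amide series

The source may hold more compounds than are shown below. What is called first, only, known or untested is meant among the compounds shown, and "the series" means these compounds.

Measured so far in a functional assay for antagonist activity at transient receptor potential cation channel subfamily V member 1 (Homo sapiens), read by FLIPR and calcium flux; a higher number here means a weaker inhibitor, a lower number a stronger inhibitor:
compound 1 `O=C1COc2ccc(NC(=O)C3CCN(c4cc(F)c(F)c(F)c4)CC3)cc2N1` gives 59 nM
compound 2 `CC(=O)N1CCc2ccc(NC(=O)C3CCN(c4cccc(C(F)(F)F)c4)CC3)cc21` gives 800 nM
compound 3 `O=C(Nc1ccc2c(c1)NC(=O)C(CCO)O2)C1CCN(c2cc(F)c(F)c(F)c2)CC1` gives 5 nM

Compound 1 sits second highest of the three numbers. Its nearest neighbour is compound 3, reached by a 12-fold lower number from compound 1 to compound 3 (1.07 log units; beyond the scatter), a change of 2-hydroxyethyl in place of hydrogen on a saturated ring carbon. For the measured compounds named here, compound 2, which differs from compound 1 both in the core and in the aryl group on the ring amine, stands furthest away with a clearly higher number; no single-place step joins it to compound 1, so its value shows only that a trifluoromethylphenyl on a different core reads weaker.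

The new compound, compound 4 `CC(C)c1ccccc1N1CCC(C(=O)Nc2ccc3c(c2)NC(=O)CO3)CC1`, differs from compound 1 by 2-isopropylphenyl in place of 3,4,5-trifluorophenyl on an amine nitrogen in a ring. Going by the values given here, none of the measured steps touches this position: the one step in hand changes the core, not the aryl group, so it gives no direct guide to size or direction here. Among the compounds with values here, compound 2 suggests only that aryl changes paired with other edits can move the number well beyond the scatter.

Within the data shown here, with no bearing step, the expectation for compound 4 is a modest weakening, a 2.5-fold higher number from compound 1 to compound 4 (0.41 log units; beyond the scatter), with wide uncertainty. Compound 4 is estimated at 150 nM, within 30 nM to 800 nM.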

Compound 4, half-maximal inhibitory concentration: 180 nM
The estimate for compound 4 lay 1.2-fold (0.08 log units) below the measured number; the measured number falls inside the stated range.
By their numbers in this assay, from the lowest: compound 3; then compound 1; then compound 4; then compound 2.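

In this assay, for the compounds shown here, this is the first single-place reading of the aryl group on the ring amine, and it runs toward weaker inhibition (a 3.1-fold higher number from compound 1 to compound 4 (0.48 log units; beyond the scatter)). The step is modest, and compound 4 keeps a measurable inhibitor number, so on the core of compound 1 this position accepts an all-carbon 2-isopropylphenyl in place of 3,4,5-trifluorophenyl, with the heavy-atom count and the donor and acceptor counts unchanged. Nothing measured on these compounds accounts for the size or direction of the step.

Because the step swaps the fluorines and the isopropyl in one move, the compounds shown do not separate the loss of fluorine from the arrival of isopropyl, and a plain phenyl, a single fluorine or a lone methyl on this ring would be needed to pull the two apart. As far as these compounds go, it also remains open whether the same aryl change carries over to the core bearing the 2-hydroxyethyl group of compound 3, and how a nitrile, a methoxy group or a ring nitrogen in the aryl group would read at this position.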